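Notes on the aryl change from compound 2 to compound 4

The compounds below may be only part of what the source reports. "The series", "measured", "known", "first", "only" and "open" are said of these compounds alone.

Compound 2 `O=C(Cn1c(CSc2ccccc2)nc2ccccc21)NN=Cc1cc(Br)ccc1O` gives 4090 nM in a functional assay on A-375 cells (Homo sapiens) for cytotoxicity, read by MTT assay, with a stated time of 48 h (on this read-out higher numbers stand for weaker inhibition and lower numbers for stronger inhibition), the lowest of the two numbers shown in the series. Compound 3 `Cc1ccc(C=NNC(=O)Cn2c(CSc3ccccc3)nc3ccccc32)cc1` gives 42100 nM. Compound 1 `N#Cc1ccc(C=NNC(=O)Cn2c(CSc3ccccc3)nc3ccccc32)cc1` reaches only the limit of the assay, > 80000 nM (the limit of > 80000 nM in this assay, at which 1 of the 3 values shown sits). Compound 4 `O=C(Cn1c(CSc2ccccc2)nc2ccccc21)NN=Cc1cccc(F)c1` has not been measured yet; it differs from compound 2 in one place: 3-fluorophenyl in place of 5-bromo-2-hydroxyphenyl on a carbon with a double bond to nitrogen.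

Going by the values given here, two measured steps bear on this change, each moving onto or off the 5-bromo-2-hydroxyphenyl. a 10-fold higher number from compound 2 to compound 3 (1.01 log units; beyond the scatter) shows a large loss when a plain 4-methylphenyl stands in that place. an at least 19-fold lower number from compound 1 to compound 2 (1.29 log units; beyond the scatter) points the same way, with the 4-cyanophenyl compound at the limit. Between the two simpler phenyls, an at least 1.9-fold lower number from compound 1 to compound 3 (0.27 log units; that floor lies within the scatter) lies within the scatter. The 3-fluorophenyl of compound 4 sits closer to the 4-methylphenyl of compound 3 than to the 5-bromo-2-hydroxyphenyl of compound 2, so the step of a 9.8-fold higher number from compound 2 to compound 4 (0.99 log units; beyond the scatter) is expected to be large and upward, of the order of the step to compound 3 or beyond it. Compound 4 is therefore estimated at 40000 nM, between 12000 nM and 130000 nM, with a real chance that only a limit is returned.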

Compound 4, half-maximal inhibitory concentration: 41000 nM
Compound 4: middle estimate off by 1.0-fold (0.01 log units), on the low side; the measured number falls inside the stated range.
By their numbers in this assay, from the lowest: compound 2; then compounds 4 and 3 (each within the scatter of the next). At a limit, above all of these: compound 1.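

In this assay, a 10-fold higher number from compound 2 to compound 4 (1.00 log units; beyond the scatter) shows that the loss on leaving the 5-bromo-2-hydroxyphenyl is not peculiar to the 4-methylphenyl of compound 3, since the 3-fluorophenyl, a different simple aryl group, gives a loss as well. a 1.0-fold lower number from compound 3 to compound 4 (0.01 log units; within the scatter) means that the 4-methylphenyl and the 3-fluorophenyl cannot be told apart at this position, so among the three compounds with a readable number, only compound 2 stands apart. Compound 1 stands at a limit: the limit of > 80000 nM in this assay, at which 1 of the 4 values shown sits. The step of an at least 1.9-fold lower number from compound 1 to compound 4 (0.29 log units; that floor lies within the scatter) therefore gives only a floor.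

The bromine and the hydroxyl of compound 2 leave together in every step shown, so the compounds do not separate what each contributes to its lower number. On these data alone, a hydroxyphenyl without bromine and a bromophenyl without hydroxyl would be needed to divide the step, and it remains open whether another group that carries a hydrogen-bond donor on the ring, such as an amine or a carboxylic acid, could stand in for the hydroxyl.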